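From isopropyl to hex-1-yn-1-yl on a shared core

This account rests on a few compounds, and the source may have more. Where it says the series, first, only, none or still open, it means among the compounds named here.

Of the compounds shown here, three with a shared core have been measured in a physicochemical assay for solubility, read by HPLC, at pH 7.4; a lower number here means a less soluble compound, a higher number a more soluble compound: compound 1 `CCc1c(C)[nH]c2cc(OC)c(Cl)cc2c1=O`, compound 2 `COc1cc2[nH]c(C)c(C3CCCCC3)c(=O)c2cc1Cl` and compound 3 `COc1cc2[nH]c(C)c(C(C)C)c(=O)c2cc1Cl`. Compound 1 gives 10000 nM and compound 2 gives 5000 nM. Compound 3 gives > 20000 nM, which is a limit of the assay and not a number.

Compound 4 `CCCCC#Cc1c(C)[nH]c2cc(OC)c(Cl)cc2c1=O` carries hex-1-yn-1-yl in place of isopropyl on an aromatic carbon. The most informative measured step is an at least 4.0-fold higher number from compound 2 to compound 3 (0.60 log units; beyond the scatter), with isopropyl in place of cyclohexyl. The steps starting from ethyl, a 2.0-fold lower number from compound 1 to compound 2 (0.30 log units; within the scatter) and an at least 2.0-fold higher number from compound 1 to compound 3 (0.30 log units; that floor lies within the scatter), offer less guidance. Taking compound 2 at 5000 nM as the nearest guide, a lower number is expected in this assay, by a step beyond the scatter. The expected change is an at least 5.0-fold lower number from compound 3 to compound 4 (0.69 log units; beyond the scatter). For compound 4 the estimated value is 4000 nM, with an expected range from 1000 nM to 15000 nM.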

Compound 4, solubility: > 20000 nM
Compound 4: a limit, no number (the forecaster's own chance of this, stated with the estimate: 10%); middle value at least 5.0-fold (0.69 log units) away from the limit.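

In this assay, hex-1-yn-1-yl in place of cyclohexyl on this aromatic carbon gives an at least 4.0-fold higher number from compound 2 to compound 4 (0.60 log units; beyond the scatter), so a group with more heavy atoms than isopropyl need not bring the number down at this position. Against ethyl, the same group gives an at least 2.0-fold higher number from compound 1 to compound 4 (0.30 log units; that floor lies within the scatter), which adds little on its own. The step between compound 3 and compound 4 cannot be read, because each of the two compounds gives a limit of the assay and not a number: the limit of > 20000 nM in this assay, at which 2 of the 4 values shown sit.

From the compounds shown here alone, how far past that limit compound 3 and compound 4 lie stays open, so isopropyl and hex-1-yn-1-yl cannot be ranked against each other. Also open, going by these compounds, is how an amine, a carboxylic acid or a saturated hexyl chain on this aromatic carbon would read in this assay.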